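Butyl to hydroxymethyl in the series: expected step

A few compounds are considered here, and "the series" means these few. Any claim that something is new, unique, unknown or untested is made for them only; others in the source may bear on it.

Measured in a functional assay on MCF7 cells (Homo sapiens) for cytotoxicity, read by neutral red uptake, with a stated time of 3 days; a higher number here means a weaker inhibitor, a lower number a stronger inhibitor:
- compound 1 `CCCCc1c(F)c(N)c2c(=O)cc(-c3ccc(N)c(F)c3)oc2c1F`: 8800 nM
- compound 2 `Nc1ccc(-c2cc(=O)c3c(N)c(F)c(Br)c(F)c3o2)cc1F`: 160 nM
- compound 3 `Nc1ccc(-c2cc(=O)c3c(N)c(F)c(O)c(F)c3o2)cc1F`: > 10000 nM

The value of compound 3 is a limit, not a number.

Compound 1 holds the higher of the two true numbers, and the step to the other is a 55-fold lower number from compound 1 to compound 2 (1.74 log units; beyond the scatter). Compound 4 `Nc1ccc(-c2cc(=O)c3c(N)c(F)c(CO)c(F)c3o2)cc1F` differs from compound 1 as follows: hydroxy in place of propyl on a saturated chain carbon bound to an aromatic carbon. This is hydroxy in place of propyl on a saturated chain carbon bound to an aromatic carbon.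

The closest measured change, hydroxy in place of butyl on an aromatic carbon, is an at least 1.1-fold higher number from compound 1 to compound 3 (0.05 log units; that floor lies within the scatter). The step from bromo is an at least 62-fold higher number from compound 2 to compound 3 (1.79 log units; beyond the scatter), and it bears less directly. No step beyond the scatter is therefore expected in this assay. The expected step is a 1.8-fold lower number from compound 1 to compound 4 (0.25 log units; within the scatter). Compound 4 is estimated at 5000 nM, with an expected range of 700 nM to 20000 nM.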

Compound 4, half-maximal inhibitory concentration: 62 nM
Beside the measured number, compound 4's estimate is 81-fold (1.91 log units) above it; the whole stated range lies above it.
By their numbers in this assay, from the lowest: compound 4; then compound 2; then compound 1. At a limit, above all of these: compound 3.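

In this assay, butyl and hydroxymethyl on this aromatic carbon are far from equivalent (a 140-fold lower number from compound 1 to compound 4 (2.15 log units; beyond the scatter)), and hydroxymethyl also goes modestly below bromo (a 2.6-fold lower number from compound 2 to compound 4 (0.41 log units; beyond the scatter)). Hydroxy set directly on the aromatic carbon and hydroxymethyl differ widely (an at least 160-fold lower number from compound 3 to compound 4 (2.20 log units; beyond the scatter)), so the presence of a hydroxy alone does not set the number in this small set. Compound 3 stands at a limit, not a number: the limit of > 10000 nM in this assay, at which 1 of the 4 values shown sits.

From the compounds shown here alone, whether the hydroxy of hydroxymethyl matters at all remains open, and methyl or methoxymethyl here would test it. Aminomethyl, a carboxylic acid or a longer hydroxyalkyl chain also remain open.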